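A few compounds are considered here, and "the series" means these few. Any claim that something is new, unique, unknown or untested is made for them only; others in the source may bear on it.

Working notes on the series. Compound 1 `CNC(=O)c1cccc(Cn2nc(C)c(NC(=O)c3ccc(COc4ccccc4)cc3)c2C)c1` gives 6200 nM in a functional assay on MIA PaCa-2 cells (Homo sapiens) for antiproliferative activity, read by MTT assay, with a stated time of 72 h; on this read-out lower numbers stand for an effect already at smaller amounts and higher numbers for an effect only at larger amounts of compound. Going by the values given here, compound 2 `CNC(=O)c1cccc(Cn2nc(C)c(NC(=O)c3ccc(COc4ccc(C)cc4)cc3)c2C)c1` gives 2600 nM in the same assay, and the step of a 2.4-fold lower number from compound 1 to compound 2 (0.38 log units; beyond the scatter) is the only measured step in the set. Among the compounds with values here, on the numbers so far compound 2 stands lowest of the two, with compound 1 as its nearest neighbour.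

Compound 3 `CNC(=O)c1cccc(Cn2nc(C)c(NC(=O)c3ccc(COc4ccc(OC)cc4)cc3)c2C)c1` is the next step from compound 2: methoxy in place of methyl on an aromatic carbon. Within the data shown here, the measured step from compound 1 to compound 2 bears on it only indirectly, since it placed a group on the same aromatic carbon, whereas here one group is swapped for another; no measured pair shows that swap. A change at most of modest size is therefore expected, in either direction, and most likely none beyond the scatter. For compound 3 the expected step is a 1.0-fold lower number from compound 2 to compound 3 (0.02 log units; within the scatter), giving an estimate of 2500 nM with a range from 1000 nM to 6000 nM.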

Compound 3, half-maximal effective concentration: 8000 nM
For compound 3 the middle estimate is 3.2-fold (0.51 log units) below the measured one; the measured number lies above the stated range.
By their numbers in this assay, from the lowest: compound 2; then compounds 1 and 3 (each within the scatter of the next).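

In this assay the group on this aromatic carbon, para to a large group, matters beyond its mere presence: methoxy in place of methyl gives a 3.1-fold higher number from compound 2 to compound 3 (0.49 log units; beyond the scatter) and so does not keep what methyl gained. Methoxy in place of hydrogen gives a 1.3-fold higher number from compound 1 to compound 3 (0.11 log units; within the scatter) and so leaves compound 3 not separated from compound 1, which makes compound 2 the only one of the three that stands apart at this position. Nothing at hand gives a reason for the difference between methyl and methoxy here.

The compounds shown leave open whether the lower number is particular to methyl or would also appear with ethyl, chlorine or an amine on this carbon. They also leave open whether methyl and methoxy would differ in the same way on another carbon of this ring.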